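The source may report more compounds than this note shows. Statements on the series, on what has been measured and on what is new or still open speak of the compounds shown alone.

Of the compounds shown here, three built on a shared core have been tested in a functional assay on A 172 cells (Homo sapiens) for cytotoxicity, read by MTT assay, with a stated time of 24 h; a higher number here means a weaker inhibitor, a lower number a stronger inhibitor. Compound 1 `C=C1C(=O)[C@H]2C[C@@H]1CC1=C2[C@]2(C)CCC[C@](C)(CO)[C@H]2CC1` returns only a limit of the assay, > 50000 nM, and not a number. Compound 2 `C[C@@H]1C(=O)[C@H]2C[C@]1(O)CC1=C2[C@]2(C)CCC[C@](C)(CO)[C@H]2CC1` likewise gives only a limit in this assay, > 50000 nM. Compound 3 `C[C@@H]1C(=O)[C@H]2C[C@]1(O)CC1=C2[C@]2(C)CCCC(C)(C)[C@H]2CC1` also stops at a limit, > 50000 nM. Compound 2 therefore stands at the same ceiling as the other two, and the values do not separate it from them. Within the data shown here, the only single-change step among the measured compounds, a step that the two limits leave unreadable from compound 2 to compound 3, cannot be read because of the limit of > 50000 nM in this assay, at which 3 of the 3 values shown sit. Compound 4 `C[C@@H]1C(=O)[C@H]2C[C@]1(O)CC1=C2[C@]2(C)CCC[C@](C)(C=O)[C@H]2CC1` differs from compound 2 by formyl in place of hydroxymethyl on a saturated ring carbon. Among the measured compounds shown here, no measured step bears directly on this change, and the one step that exists, hydrogen in place of hydroxy, is itself unreadable, so nothing in this assay points toward a gain or a loss. Compound 4 is expected to sit near the same limit, with the step that the limit leaves unreadable from compound 2 to compound 4 estimated to stay within the scatter. The estimate for compound 4 in this assay is 60000 nM, with a range from 20000 nM to 200000 nM.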

Compound 4, half-maximal inhibitory concentration: > 50000 nM
Compound 4: no number, only a limit; the forecaster's own chance of this, stated with the estimate: 80%; the middle value lies beyond the limit too.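

No size can be read for the change from compound 2 to compound 4, formyl in place of hydroxymethyl, because both compounds stop at a limit and not a number: the limit of > 50000 nM in this assay, at which 4 of the 4 values shown sit.

The compounds shown leave open whether any change to the shared core can bring a measurable value in this assay, and so which groups matter there.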